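Phenyl to Pyridyl with a Shifted Thiophene on a Purine Core

The source may report more compounds than this note shows. Statements on the series, on what has been measured and on what is new or still open speak of the compounds shown alone.

Compound 2 `NC1CCC(Nc2nc(NCc3ccc(-c4ccsc4)cc3)c3ncn(C4CCCC4)c3n2)CC1` gives 570 nM in a functional assay on G-361 cells (Homo sapiens) for inhibition, with a stated time of 72 h (on this read-out higher numbers stand for weaker inhibition and lower numbers for stronger inhibition), the lower of the two numbers shown, though compound 1 `NC1CCC(Nc2nc(NCc3ccc(-c4cccc(F)c4)cc3)c3ncn(C4CCCC4)c3n2)CC1` with 815 nM lies within the scatter of it, as the step of a 1.4-fold lower number from compound 1 to compound 2 (0.16 log units; within the scatter) confirms. Compound 3 `NC1CCC(Nc2nc(NCc3ccc(-c4cccs4)nc3)c3ncn(C4CCCC4)c3n2)CC1` carries 6-(thiophen-2-yl)pyridin-3-yl in place of 4-(thiophen-3-yl)phenyl on a saturated chain carbon bound to a nitrogen on an aromatic ring. Within the data shown here, only that single measured step exists, and it does not touch the ring that now changes, so no shift beyond the scatter is anticipated for compound 3. The expected step is a 1.1-fold higher number from compound 2 to compound 3 (0.02 log units; within the scatter), and compound 3 is estimated at 600 nM, with a range from 250 nM to 1500 nM.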

Compound 3, half-maximal inhibitory concentration: 150 nM
The estimate for compound 3 lay 4.0-fold (0.60 log units) above the measured number; the measured number lies below the stated range.
By their numbers in this assay, from the lowest: compound 3; then compounds 2 and 1 (each within the scatter of the next).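

Swapping in 6-(thiophen-2-yl)pyridin-3-yl gave a 3.8-fold lower number from compound 2 to compound 3 (0.58 log units; beyond the scatter) in this assay, the first change in this set to move the number beyond the scatter. This position, on a saturated chain carbon bound to a nitrogen on an aromatic ring, therefore responds to a change in the ring pair it carries. No measurement explains this step. The ring nitrogen and the shifted thiophene attachment changed together, so their shares remain unresolved. A 4-(thiophen-2-yl)phenyl group or a 6-(thiophen-3-yl)pyridin-3-yl group in this place would separate them.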